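Removing the chloro from a sigma-1 ligand

The source may hold more compounds than are shown below. What is called first, only, known or untested is meant among the compounds shown, and "the series" means these compounds.

Measured so far:
Compound 1: `Cc1ccc(CN(C)CCCCn2c(=O)oc3ccccc32)c(C)c1`, 239 nM
Compound 2: `CN(CCCCn1c(=O)oc2ccccc21)Cc1ccc(Cl)cc1`, 7.1 nM

In an assay on membranes from liver for displacement of a labelled ligand from Sigma non-opioid intracellular receptor 1 (Rattus norvegicus), read by scintillation counting (a higher number here means a weaker inhibitor, a lower number a stronger inhibitor), compound 2 gives 7.1 nM, the lower of the two numbers, and so the stronger binder of the pair. Going by the values given here, its only measured neighbour is compound 1, which gives 239 nM; the step between them, a 34-fold lower number from compound 1 to compound 2 (1.53 log units; beyond the scatter), came from swapping the ring that hangs on the amine nitrogen.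

Compound 3, `CN(CCCCn1c(=O)oc2ccccc21)Cc1ccccc1`, is the next step from compound 2: hydrogen in place of chloro on an aromatic carbon. Among the compounds with values here, the change is small in atoms, but it sits on the very ring where the one measured step was large. That step, however, altered two substituents at once, so it only loosely bears on the loss of the chloro alone. Nothing measured here isolates that single group.

The expectation is therefore a moderate weakening rather than another large swing, and the estimated step is a 3.5-fold higher number from compound 2 to compound 3 (0.55 log units; beyond the scatter). Compound 3 is expected to give about 25 nM, most likely between 8 nM and 80 nM.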

Compound 3, inhibition constant: 2.6 nM
Compound 3: middle estimate off by 9.6-fold (0.98 log units), on the high side; measured number below the stated range.
By their numbers in this assay, from the lowest: compound 3; then compound 2; then compound 1.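

In this assay, the chloro proves unnecessary for strong binding at this aromatic carbon: replacing it with hydrogen gives a 2.7-fold lower number from compound 2 to compound 3 (0.44 log units; beyond the scatter) and moves the number down, not up. The bare phenyl also stands furthest from the 2,4-dimethylphenyl, with a 92-fold lower number from compound 1 to compound 3 (1.96 log units; beyond the scatter) on that single change, so among these three compounds the ring with no substituent gives the lowest number, and neither the 4-chlorophenyl nor the 2,4-dimethylphenyl improves on it. No supporting measurement is available to explain why the number falls when the chloro leaves.

Going by these compounds, it remains open whether the chloro is a special case or whether any group at this place gives a higher number than hydrogen; a fluoro, a methoxy or a single methyl on the same aromatic carbon would help to separate those two readings. The two methyls of compound 1 also remain unresolved, since a phenyl ring carrying only the 2-methyl or only the 4-methyl would show whether one of them accounts for most of the distance from compound 3.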